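The source may report more compounds than this note shows. Statements on the series, on what has been measured and on what is new or still open speak of the compounds shown alone.

Measured so far in an ADME assay on the whole organism (plasma) for pharmacokinetics, with Rattus norvegicus as the target, at a dose of 3 mg/kg by the oral route; a higher number here means more compound in the circulation at the dose given, a lower number less compound in the circulation

Compound 1 `COC(=O)N[C@H](C(=O)N1CCC[C@H]1C(=O)Nc1ccc([C@H]2CC[C@H](c3ccc(NC(=O)[C@@H]4CCCN4C(=O)[C@@H](NC(=O)OC)C(C)C)cc3)N2c2ccc(C(F)(F)F)cc2)cc1)C(C)C` gives 1360 ng.h/mL
Compound 2 `COC(=O)N[C@H](C(=O)N1CCC[C@H]1C(=O)Nc1ccc([C@H]2CC[C@H](c3ccc(NC(=O)[C@@H]4CCCN4C(=O)[C@@H](NC(=O)OC)C(C)(C)C)cc3)N2c2ccc(F)cc2)cc1)C(C)(C)C` gives 10200 ng.h/mL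

Compound 2 stands highest of these two numbers, and its gap to compound 1 lies beyond the usual scatter of repeated measurements. The next compound to be tested is compound 3 `COC(=O)N[C@H](C(=O)N1CCC[C@H]1C(=O)Nc1ccc([C@@H]2CC[C@@H](c3ccc(NC(=O)[C@@H]4CCCN4C(=O)[C@@H](NC(=O)OC)C(C)(C)C)cc3)N2c2ccc(F)cc2)cc1)C(C)(C)C`. Its relation to compound 2 is a purely three-dimensional one: the two compounds have the same atoms and bonds and differ only in configuration as drawn: 2 of 6 stereo elements differ; a stereocentre at a saturated ring carbon is drawn R in compound 2 and S in compound 3; a stereocentre at a saturated ring carbon is drawn R in compound 2 and S in compound 3. Such compounds are drawn with the same connections but are different molecules, and they need not behave alike in an animal.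

Among the compounds with values here, no measured pair here differs in one place only, so the data offer no direct guide to the size of this step. The direction is therefore a cautious judgement. Within the data shown here, since compound 2 holds 10200 ng.h/mL, the higher of only two numbers, a fall seems more likely than a rise, although a result within the scatter remains possible. The expected change is a 2.3-fold lower number from compound 2 to compound 3 (0.36 log units; beyond the scatter). For compound 3 the estimate is 4500 ng.h/mL, with an expected range of 1000 ng.h/mL to 15000 ng.h/mL.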

Compound 3, area under the concentration-time curve in the Rattus norvegicus assay: 1850 ng.h/mL
Compound 3: middle estimate off by 2.4-fold (0.39 log units), on the high side; the range from low to high includes it.
By their numbers in the Rattus norvegicus assay, from the lowest: compounds 1 and 3 (each within the scatter of the next); then compound 2.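

In the Rattus norvegicus assay compound 1 gives 1360 ng.h/mL and compound 2 gives 10200 ng.h/mL; these two differ in more than one place, so their gap could not be tied to any single feature, whereas compounds 2 and 3 isolate the spatial arrangement at two saturated ring carbons. In the Rattus norvegicus assay, reversing the configuration at those two stereocentres gives a 5.5-fold lower number from compound 2 to compound 3 (0.74 log units; beyond the scatter), and this step can be assigned to configuration alone because no atom or bond changes: the fact that compounds 2 and 3 differ only in the configuration as drawn

In a physicochemical assay for solubility, in phosphate buffer, measured as kinetic solubility, at pH 7.2 (on this read-out lower numbers stand for lower solubility and higher numbers for higher solubility), compound 2 gives 3900 nM and compound 3 gives 4400 nM, which is a 1.1-fold higher number from compound 2 to compound 3 (0.05 log units; within the scatter), so this read-out does not separate the two stereoisomers, even though the amount in the circulation does.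

Both stereocentres change together here, which leaves open how much each one contributes and whether the result reflects uptake from the gut, removal from the body or both. As far as these compounds go, it also remains open whether configuration would matter to the same extent with another group in place of the fluorine on the shared core, such as a nitrile or an amine.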